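The source may hold more compounds than are shown below. What is called first, only, known or untested is meant among the compounds shown, and "the series" means these compounds.

Three compounds built on one shared core have been examined in an assay on isolated protein for inhibition of Leucine-rich repeat serine/threonine-protein kinase 2 (Homo sapiens), read by TR-FRET and LanthaScreen, with stated times of 50 min and 30 min, in the presence of a further agent that is not named here; a higher number here means a weaker inhibitor, a lower number a stronger inhibitor. Compound 1, `Cc1c(Nc2nc(N)c3c(C#N)c(N4CCC[C@H]4C)n(C)c3n2)cnn1C`, gives 75 nM. Compound 2, `Cc1c(Nc2nc(N)c3c(C#N)c(N4CCC[C@H]4C)n(C)c3n2)cnn1CC1(O)COC1`, gives 16 nM. Compound 3, `Cc1nn(C)cc1Nc1nc(N)c2c(C#N)c(N3CCC[C@H]3C)n(C)c2n1`, gives 38 nM.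

Compound 2 differs from compound 1 only by 3-hydroxyoxetan-3-yl in place of hydrogen on a saturated chain carbon bound to an aromatic nitrogen. This change produced a 4.7-fold lower number from compound 1 to compound 2 (0.67 log units; beyond the scatter).

Compound 3 and compound 1 have the same atoms joined differently; the difference between the two cores is 1,3-dimethyl-1H-pyrazol-4-yl in place of 1,5-dimethyl-1H-pyrazol-4-yl on a nitrogen on an aromatic ring. Between these two compounds the result was a 2.0-fold lower number from compound 1 to compound 3 (0.30 log units; within the scatter), so the two values cannot be separated.

A fourth compound, compound 4, `Cc1nn(CC2(O)COC2)cc1Nc1nc(N)c2c(C#N)c(N3CCC[C@H]3C)n(C)c2n1`, has not yet been measured in this assay. Among the compounds with values here, it is related to compound 3 by 3-hydroxyoxetan-3-yl in place of hydrogen on a saturated chain carbon bound to an aromatic nitrogen, which is the same change that separates compound 1 from compound 2, at the same place, and so far it has been seen only in that one measured pair.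

Because a 4.7-fold lower number from compound 1 to compound 2 (0.67 log units; beyond the scatter) was seen when the same change was made on the core of compound 1, a comparable step is expected on the core of compound 3, namely a 4.2-fold lower number from compound 3 to compound 4 (0.63 log units; beyond the scatter). That expectation rests on a single precedent, and the two cores are not identical, so the range is kept fairly wide. On that basis compound 4 is estimated to give 9 nM in this assay, with the expected range running from 4 nM to 25 nM.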

Compound 4, half-maximal inhibitory concentration: 57 nM
For compound 4 the middle estimate is 6.3-fold (0.80 log units) below the measured one; the measured number lies above the stated range.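

In this assay, placing 3-hydroxyoxetan-3-yl on the core of compound 3 gave a 1.5-fold higher number from compound 3 to compound 4 (0.18 log units; within the scatter), so the two values cannot be separated and this core shows no measurable effect of the change. Set beside the earlier pair, the change does not carry over from one core to the other at the same size, even though the two cores differ only in 1,3-dimethyl-1H-pyrazol-4-yl against 1,5-dimethyl-1H-pyrazol-4-yl: the same change on two cores in this assay, a 4.7-fold lower number (0.67 log units; beyond the scatter) from compound 1 to compound 2 and a 1.5-fold higher number (0.18 log units; within the scatter) from compound 3 to compound 4, 7.0-fold (0.85 log units) apart, beyond the scatter of two such steps This rests on just two pairs, so it shows that the step depends on the core in these compounds, but it does not show why, nor how the change would behave on any further core in the series.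

At this place the compounds shown carry only hydrogen or 3-hydroxyoxetan-3-yl, which leaves open whether a simpler 2-hydroxyethyl group, a longer chain or an amine would also give different steps on the two cores. Going by these compounds, it also remains open whether other cores would follow the pair of compound 1 and compound 2 or the pair of compound 3 and compound 4.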